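The source may hold more compounds than are shown below. What is called first, only, known or untested is meant among the compounds shown, and "the series" means these compounds.

Measured compounds in a functional assay on SK-MEL-2 cells (Homo sapiens) for inhibition, read by sulforhodamine B assay, with a stated time of 48 h; a lower number here means a stronger inhibitor of growth, a higher number a weaker inhibitor of growth:
compound 1, `Nc1cc(N)c2nc(-c3ccccc3)c(Oc3ccc(Cl)c(Cl)c3)nc2c1`, 5620 nM
compound 2, `COc1ccc(CNc2nc3cc(N)cc(N)c3nc2-c2ccccc2)cc1`, 14800 nM

Compound 1 holds the lowest of the two numbers in this assay; the nearest, compound 2, stands above it by a gap beyond the scatter. Within the data shown here, no two measured compounds differ in only one place, so no single-change step can be read from the data.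

Compound 3, `Nc1cc(N)c2nc(-c3ccccc3)c(Sc3ccc(F)cc3)nc2c1`, has not yet been measured in this assay. It differs from compound 1 in one place: (4-fluorophenyl)sulfanyl in place of 3,4-dichlorophenoxy on an aromatic carbon. Nothing measured in the series shows what this kind of change does, so the step is judged on the two measured values alone. The expectation is a modest move towards a higher number, roughly at the edge of the scatter, and the estimated step is a 1.4-fold higher number from compound 1 to compound 3 (0.15 log units; within the scatter). Compound 3 is therefore expected to give about 8000 nM, with a range from 2500 nM to 25000 nM.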

Compound 3, concentration for 50% growth inhibition: 38000 nM
Compound 3: the middle estimate sits 4.8-fold (0.68 log units) below what was measured, outside the stated range (above it).
By their numbers in this assay, from the lowest: compound 1; then compound 2; then compound 3.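

In this assay, among these compounds, (4-fluorophenyl)sulfanyl in place of 3,4-dichlorophenoxy on the aromatic carbon next to the ring nitrogen gives a 6.8-fold higher number from compound 1 to compound 3 (0.83 log units; beyond the scatter) and so provides the first single-place reading: growth inhibition responds to the group at this position. The change replaces the oxygen link with sulfur and the two chlorines with one fluorine at the same time, so the step cannot be divided between the link and the ring substituents. No measurement available here explains the rise.

A 4-fluorophenoxy group or a 3,4-dichlorophenylsulfanyl group would separate the link from the ring substituents. Going by these compounds, whether this position needs an aryl ring at all remains open, and a simple methoxy group or a short alkyl chain there would test it.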